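Bromo to amino swap: notes on compound 4

A few compounds are considered here, and "the series" means these few. Any claim that something is new, unique, unknown or untested is made for them only; others in the source may bear on it.

Values so far in an ADME assay on MDCK cells (Canis lupus familiaris) for cytotoxicity, read by MTT assay, with a stated time of 24 h (on this read-out higher numbers stand for lower toxicity in this test and lower numbers for higher toxicity in this test), for the series:
- compound 1 `N#CCCN(Cc1cccs1)S(=O)(=O)c1ccc(Br)cc1` gives > 173000 nM (a limit)
- compound 2 `N#CCCN(Cc1cccs1)S(=O)(=O)c1ccc(C(F)(F)F)cc1` gives > 178000 nM (a limit)
- compound 3 `N#CCCN(Cc1cccs1)S(=O)(=O)c1ccc([N+](=O)[O-])cc1` gives > 189000 nM (a limit)

Compound 1 is known only as the limit > 173000 nM and not as a number. Compound 2 and compound 3 are also known only as limits.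

Compound 4 `N#CCCN(Cc1cccs1)S(=O)(=O)c1ccc(N)cc1` is not yet measured and differs from compound 1 as follows: amino in place of bromo on an aromatic carbon In words, this is amino in place of bromo on an aromatic carbon.

Two measured replacements of the same bromo bear on this change: a step that the two limits leave unreadable from compound 1 to compound 2 and a step that the two limits leave unreadable from compound 1 to compound 3 and neither gives a size. The remaining measured step, a step that the two limits leave unreadable from compound 2 to compound 3 gives none either.

With no measured size to carry over, the step expected in this assay is a step that the limit leaves unreadable from compound 1 to compound 4 with no direction favoured. Another limit rather than a number is the likely report. Compound 4 is estimated at 207000 nM with an expected range of 80000 nM to 210000 nM for this read-out.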

Compound 4, half-maximal cytotoxic concentration: > 207000 nM
Compound 4 gave a limit, no number (the forecaster's own chance of this, stated with the estimate: 85%); the middle value lies on the limit itself.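

Within the data shown here, compound 1, compound 2, compound 3 and compound 4 all stand as limits in this assay, and no step from compound 4 to the others can be read. The compounds shown leave open whether the bromo, trifluoromethyl, nitro and amino compounds differ at all in this read-out.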